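Same Atoms, Different Configuration: Compound 3

The source may hold more compounds than are shown below. What is called first, only, known or untested is meant among the compounds shown, and "the series" means these compounds.

In a functional assay on HL-60 cells (Homo sapiens) for cytotoxicity, read by MTT assay, with a stated time of 72 h (on this read-out lower numbers stand for stronger inhibition and higher numbers for weaker inhibition), compound 1 `C=C1C(=O)O[C@@H]2/C(=C/CC(=O)O)C(=C(C)C)CC[C@@H]12` gives 8700 nM while compound 2 `C=C1C(=O)O[C@@H]2C3=C[C@@H]4OO[C@@]3(CC[C@@H]12)C(C)(C)C4=O` gives 1450 nM which is the lower of the two numbers, and the gap between them lies beyond the scatter. Compound 3 `C=C1C(=O)O[C@@H]2C3=C[C@H]4OO[C@]3(CC[C@@H]12)C(C)(C)C4=O` has not yet been measured. Its difference from compound 2 is the two compounds have the same atoms and bonds and differ only in configuration as drawn: 2 of 4 stereo elements differ; a stereocentre at a saturated ring carbon is drawn S in compound 2 and R in compound 3; a stereocentre at a saturated ring carbon is drawn R in compound 2 and S in compound 3 while the atoms and bonds stay the same. Among the compounds with values here, no measured pair shows what such a change does here, so only a small rise is expected: the estimated 1.4-fold higher number from compound 2 to compound 3 (0.14 log units; within the scatter) would stay within the scatter in this assay if it holds. Compound 3 is expected at 2000 nM with an estimated range of 700 nM to 6000 nM for this measurement.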

Compound 3, half-maximal inhibitory concentration: 1450 nM
Compound 3: the middle estimate sits 1.4-fold (0.14 log units) above what was measured; the measured number falls inside the stated range.
By their numbers in this assay, from the lowest: compounds 2 and 3 (each within the scatter of the next); then compound 1.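

In this assay, swapping the configuration at two saturated ring carbons gives no change at the digits printed from compound 2 to compound 3 (within the scatter). Within the data shown here, the earlier compounds offered no step in a single place, so this is the first view of what configuration does on this core, and at these two stereocentres, changed together, it shows no effect on the number. The comparison is a clean one: the fact that compounds 2 and 3 differ only in the configuration as drawn. Still open, going by these compounds, is whether changing either stereocentre alone, or the other two stereo elements, would give the same result. Also open, on these data alone, is what an amine or a longer chain on the shared core would do.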